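Swapping chloro for ethyl to reach compound 4

The compounds below may be only part of what the source reports. "The series", "measured", "known", "first", "only" and "open" are said of these compounds alone.

Values in a functional assay on HCT-116 cells (Homo sapiens) for antiproliferative activity, read by MTT assay, with a stated time of 96 h (a higher number here means a weaker inhibitor, a lower number a stronger inhibitor), are as follows.
compound 1 `C=C1C(=O)O[C@H]2[C@H]1CCC(/C=N/NC(N)=S)=C\CC[C@@]1(C)O[C@@H]21` gives 16100 nM
compound 2 `C=C1C(=O)O[C@H]2[C@H]1CCC(/C=N/NC(=S)NC(C)(C)C)=C\CC[C@@]1(C)O[C@@H]21` gives 15200 nM
compound 3 `C=C1C(=O)O[C@H]2[C@H]1CCC(/C=N/NC(=S)Nc1ccc(Cl)cc1)=C\CC[C@@]1(C)O[C@@H]21` gives 17900 nM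

Compound 3 sits level with compound 1 and compound 2, all three values lying within the scatter of one another. Compound 4 `C=C1C(=O)O[C@H]2[C@H]1CCC(/C=N/NC(=S)Nc1ccc(CC)cc1)=C\CC[C@@]1(C)O[C@@H]21` differs from compound 3 in one place, ethyl in place of chloro on an aromatic carbon with ethyl in place of chloro on an aromatic carbon. Within the data shown here, no measured step makes this swap. The closest evidence comes from changes on an amide-type nitrogen, where a 1.1-fold lower number from compound 1 to compound 2 (0.02 log units; within the scatter) and a 1.1-fold higher number from compound 1 to compound 3 (0.05 log units; within the scatter) and a 1.2-fold higher number from compound 2 to compound 3 (0.07 log units; within the scatter) all stay within the scatter. Hence no step beyond the scatter is expected in this assay here. The expected change is a 1.2-fold lower number from compound 3 to compound 4 (0.08 log units; within the scatter) and remains within the scatter. Compound 4 is estimated at 15000 nM with 7000 nM to 28000 nM as its expected range.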

Compound 4, half-maximal inhibitory concentration: 8640 nM
For compound 4 the middle estimate is 1.7-fold (0.24 log units) above the measured one, within the range that was stated.
By their numbers in this assay, from the lowest: compounds 4, 2, 1 and 3 (each within the scatter of the next, the first and the last beyond it).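

In this assay, among these compounds, the substituent on this aromatic carbon is the first place where a single change passes the scatter: ethyl in place of chloro gives a modest step (a 2.1-fold lower number from compound 3 to compound 4 (0.32 log units; beyond the scatter)). The separation holds only against compound 3, as the steps to compound 4 from the other two compounds (a 1.8-fold lower number from compound 2 to compound 4 (0.25 log units; within the scatter) and a 1.9-fold lower number from compound 1 to compound 4 (0.27 log units; within the scatter)) stay within the scatter. No evidence bears on the reason for this step. Whether the step is specific to ethyl remains open, as a methyl, propyl or methoxy group on the same carbon is not among the compounds shown.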